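Cyclohexyl in place of 4-methylphenyl

The compounds below may be only part of what the source reports. "The series", "measured", "known", "first", "only" and "open" are said of these compounds alone.

Going by the values given here, in a functional assay on A-375 cells (Homo sapiens) for antiproliferative activity, read by MTT assay, with a stated time of 72 h (on this read-out lower numbers stand for stronger inhibition and higher numbers for weaker inhibition), compound 1 (`COc1ncc(-c2ccc3c(c2)N(c2ccc(C)cc2)C(=O)CO3)cc1NS(=O)(=O)c1ccc(F)cc1`) gives 12900 nM and compound 2 (`O=C1COc2ccc(-c3cccc(NS(=O)(=O)c4ccc(F)cc4)c3)cc2N1`) gives 20100 nM as the only other number so far, the pair lying within the scatter of each other. Compound 3 (`COc1ncc(-c2ccc3c(c2)N(C2CCCCC2)C(=O)CO3)cc1NS(=O)(=O)c1ccc(F)cc1`), not yet measured, carries cyclohexyl in place of 4-methylphenyl on an amide-type nitrogen in a ring. Among the compounds with values here, no measured pair shows this change, so this assay is expected to give a 1.2-fold higher number from compound 1 to compound 3 (0.07 log units; within the scatter) as a step within the scatter. Compound 3 is estimated at 15000 nM with an expected range (6000 nM to 40000 nM).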

Compound 3, half-maximal inhibitory concentration: > 40000 nM
Compound 3 ended at the assay's limit; the forecaster's own chance of this, stated with the estimate: 15%; middle value at least 2.6-fold (0.42 log units) from the limit.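

In this assay, going by these compounds alone, the group on the amide-type nitrogen in a ring proves not to be interchangeable: cyclohexyl in place of 4-methylphenyl gives an at least 3.1-fold higher number from compound 1 to compound 3 (0.49 log units; beyond the scatter), the only step read so far, and it lies beyond the scatter. The reading for compound 3 is a limit of the assay and not a number: the limit of > 40000 nM in this assay, at which 1 of the 3 values shown sits.

From the compounds shown here alone, how far compound 3 lies past that limit stays open, so the full size of the step is unknown. Also open, going by these compounds, is whether benzyl, methyl or 4-methoxyphenyl at this position would keep the number of compound 1.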